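Methyl to Hydrogen on the Anilino Group of Compound 1

The source may report more compounds than this note shows. Statements on the series, on what has been measured and on what is new or still open speak of the compounds shown alone.

For the measured compounds named here, compound 1 `Cc1ccc(NC2=CC(=O)c3nc4n(c3C2=O)[C@H]2OC[C@@H](O)[C@H]2OC4)cc1` is one of three compounds measured in a functional assay on ECa-109 cells for inhibition, with ECa-109 cell line (Homo sapiens) as the target, read by sulforhodamine B assay (a higher number here means a weaker inhibitor, a lower number a stronger inhibitor), where compound 1 gives 3480 nM. Compound 2 `COc1cccc(NC2=CC(=O)c3c(nc4n3[C@H]3OC[C@@H](O)[C@H]3OC4)C2=O)c1` gives 3340 nM and compound 3 `COc1ccc(NC2=CC(=O)c3c(nc4n3[C@H]3OC[C@@H](O)[C@H]3OC4)C2=O)cc1` gives 3410 nM. Compound 1 has the highest of the three numbers, yet its gaps to compound 2 and to compound 3 both lie within the scatter. Going by the values given here, the single measured step, a 1.0-fold higher number from compound 2 to compound 3 (0.01 log units; within the scatter), puts 4-methoxyphenyl in place of 3-methoxyphenyl and is within the scatter. Compound 4 `O=C1C=C(Nc2ccccc2)C(=O)c2c1nc1n2[C@H]2OC[C@@H](O)[C@H]2OC1` differs from compound 1 by hydrogen in place of methyl on an aromatic carbon. Among the compounds with values here, no measured step removes a methyl, so the only guide is that the one change on the anilino group left the number unchanged. The step of a 1.0-fold higher number from compound 1 to compound 4 (0.00 log units; within the scatter) is therefore expected to stay within the scatter. Compound 4 is estimated at 3500 nM, between 1700 nM and 7200 nM.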

Compound 4, half-maximal inhibitory concentration: 4970 nM
Compound 4: middle estimate off by 1.4-fold (0.15 log units), on the low side; the range from low to high includes it.
By their numbers in this assay, from the lowest: compounds 2, 3, 1 and 4 (each within the scatter of the next).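

Taking the methyl off the 4-methylphenyl group to leave phenyl gives a 1.4-fold higher number from compound 1 to compound 4 (0.15 log units; within the scatter) in this assay. The earlier compounds shown here only showed a methoxy group at two places on the ring; this step shows that, at the place para to a large group, hydrogen reads the same as methyl within the scatter. No evidence on the cause of this result is available here. The compounds shown leave open whether a carboxylic acid, an amine or a longer chain at this place would give a step beyond the scatter.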